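Swapping a fluorobenzyl ether for an allyl ether

The source may hold more compounds than are shown below. What is called first, only, known or untested is meant among the compounds shown, and "the series" means these compounds.

Measured so far:
compound 1 `CN(C)CCNc1ccnc2cc(OCc3ccc(F)cc3)ccc12` gives 370 nM in a functional assay on HCT-116 cells (Homo sapiens) for cytotoxicity, read by MTT assay, with a stated time of 48 h; a higher number here means a weaker inhibitor, a lower number a stronger inhibitor;
compound 2 `CC(C)COc1ccc2c(Cl)ccnc2c1` gives 2490 nM;
compound 3 `Clc1ccnc2cc(OCc3ccccc3)ccc12` gives 2470 nM.

Compound 1 has the lowest number of the three, and both compound 2 and compound 3 stand beyond the scatter above it. Compound 4 `C=CCOc1ccc2c(NCCN(C)C)ccnc2c1` differs from compound 1 only at the ether: vinyl in place of 4-fluorophenyl on a saturated chain carbon bound to an oxygen on an aromatic ring. Among the measured compounds shown here, the one measured step touching that same place is a 1.0-fold lower number from compound 2 to compound 3 (0.00 log units; within the scatter), which changed nothing beyond the scatter, though it exchanged a different pair of groups. With only that to go on, the step from compound 1 to compound 4 is expected to be small, perhaps slightly upward, at a 1.5-fold higher number from compound 1 to compound 4 (0.17 log units; within the scatter). Compound 4 is therefore estimated at 550 nM, within a range of 200 nM to 1600 nM.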

Compound 4, half-maximal inhibitory concentration: 860 nM
The estimate for compound 4 lay 1.6-fold (0.19 log units) below the measured number; measured number inside the range.
By their numbers in this assay, from the lowest: compound 1; then compound 4; then compounds 3 and 2 (each within the scatter of the next).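

In this assay, a 2.3-fold higher number from compound 1 to compound 4 (0.37 log units; beyond the scatter) shows that the group on this ether affects the number, which the earlier step, a 1.0-fold lower number from compound 2 to compound 3 (0.00 log units; within the scatter), did not reveal. This change removes the aromatic ring of the 4-fluorobenzyl group, yet the step remains modest, so on the core of compound 1 that ring is not essential for a number in this range. Nothing measured here explains the step.

As far as these compounds go, whether the step follows from losing the fluorine or the whole ring remains open. So does how a saturated propyl chain or a longer hexyl chain would behave at this place.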